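The compounds below may be only part of what the source reports. "The series", "measured", "known", "first", "only" and "open" are said of these compounds alone.

Compound 1 `CCCCCCNC(=O)CC1CCc2cc(OC)c(OC)cc21` and compound 2 `COc1cc2c(cc1OC)C(CC(=O)NCc1ccccc1)CC2` share one core and differ only in the amide substituent. In a functional assay on the whole organism (strain Wistar) for inhibition, with Rattus norvegicus as the target, read by paw edema, with stated times of 60 min and 3 h, at a dose of 100 mg/kg by the oral route (on this read-out higher numbers stand for more inhibition at the one dose given (going by the name of the read-out) and lower numbers for less inhibition), compound 1 gives 44.6%, while compound 2 gives 14.5%, the lower of the two numbers, and the step of a number 30.1 percentage points lower from compound 1 to compound 2 (beyond the scatter) lies beyond the scatter. Compound 3 `COc1cc2c(cc1OC)C(CC(=O)N1CCOCC1)CC2` is not yet measured; it carries the change (morpholin-4-yl in place of benzylamino on a carbonyl carbon). Within the data shown here, no measured step matches this change; the only step known, which replaced pentyl by phenyl, reduced inhibition, and the new change removes the ring again. An increase is therefore expected, with compound 3 estimated at 28% (range 5% to 50%), a step of a number 13.5 percentage points higher from compound 2 to compound 3 (beyond the scatter), uncertain in size.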

Compound 3, a percentage reported as inhibition, in the whole organism at one dose (the size of the read-out at that dose, not a potency): 19.6%
For compound 3 the middle estimate is 8.4 percentage points above the measured one, within the range that was stated.
By their numbers in this assay, from the lowest: compounds 2 and 3 (each within the scatter of the next); then compound 1.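

In this assay, morpholin-4-yl in place of benzylamino on a carbonyl carbon gives a number 5.1 percentage points higher from compound 2 to compound 3 (within the scatter), so these two ring-bearing groups are not separated at this position. Morpholin-4-yl in place of hexylamino gives a number 25 percentage points lower from compound 1 to compound 3 (beyond the scatter), which leaves the open-chain hexylamino of compound 1 apart from both ring-bearing groups among these three compounds. Nothing at hand accounts for either step. Open, on these data alone, is whether a longer chain such as octylamino would stay with compound 1, and whether a piperidin-1-yl group would stay with compound 2 and compound 3.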